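A few compounds are considered here, and "the series" means these few. Any claim that something is new, unique, unknown or untested is made for them only; others in the source may bear on it.

In a functional assay on SH-SY5Y cells (Homo sapiens) for cytotoxicity, read by MTT assay, with a stated time of 72 h (a lower number here means a stronger inhibitor, a higher number a weaker inhibitor), compound 1 `CN1CCN(CCCCCn2c3c(c4ccccc42)C(=O)c2c[n+]([O-])c4ccccc4c2C3=O)CC1` gives 830 nM, the highest of the two numbers shown. Compound 2 `O=C1c2c[n+]([O-])c3ccccc3c2C(=O)c2c1c1ccccc1n2Cc1cn([C@@H]2C[C@H](O)[C@@H](CO)O2)nn1` gives 150 nM. Compound 3 `CC1(C)OC[C@@H](Cn2cc(Cn3c4c(c5ccccc53)C(=O)c3c[n+]([O-])c5ccccc5c3C4=O)nn2)O1` reaches only a limit of the assay, > 1000 nM, which is the limit of > 1000 nM in this assay, at which 1 of the 3 values shown sits. Compound 4 `CN1CCN(CCCCn2c3c(c4ccccc42)C(=O)c2c[n+]([O-])c4ccccc4c2C3=O)CC1` has not yet been measured; it differs from compound 1 by 4-methylpiperazin-1-yl in place of (4-methylpiperazin-1-yl)methyl on a saturated chain carbon, four bonds along the chain from an aromatic nitrogen. Among the measured compounds shown here, the only measured step, an at least 6.6-fold higher number from compound 2 to compound 3 (0.82 log units; beyond the scatter), alters a different part of the shared core, so no measured step bears directly on the change from compound 1 to compound 4. For the measured compounds named here, nothing among the measured compounds speaks for a large shift, so the expected step of a 1.0-fold lower number from compound 1 to compound 4 (0.02 log units; within the scatter) is none beyond the scatter. Compound 4 is therefore estimated at 800 nM, with a likely range from 300 nM to 2200 nM.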

Compound 4, half-maximal inhibitory concentration: 100 nM
Compound 4: the middle estimate sits 8.0-fold (0.90 log units) above what was measured, and the stated range ends above it.
By their numbers in this assay, from the lowest: compounds 4 and 2 (each within the scatter of the next); then compound 1. At a limit, above all of these: compound 3.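

Shortening the chain that carries the 4-methylpiperazin-1-yl group gives an 8.3-fold lower number from compound 1 to compound 4 (0.92 log units; beyond the scatter) in this assay, so this position responds to chain length. Among the compounds shown here, the earlier compounds could not show this, since their only measured step lay elsewhere on the shared core. No measurement shown explains the size of this step.

With only these two chain lengths, no trend can be claimed. Still open, from the compounds shown here alone, are a shorter chain, 3-(4-methylpiperazin-1-yl)propyl, and whether another amine, such as morpholine, behaves the same way on the butyl chain.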